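The compounds below may be only part of what the source reports. "The series", "measured", "known", "first", "only" and "open" are said of these compounds alone.

Compound 1 `COc1ccc(S(=O)(=O)c2cnc3ccc(C)cc3c2N2CCC(C)CC2)cc1Cl` gives 93% in an assay on isolated protein for displacement of a labelled ligand from metabotropic glutamate receptor 5 (Homo sapiens), with a stated time of 60 min, tested at 1 uM; a lower number here means less inhibition, a higher number more inhibition at the concentration tested (going by the name of the read-out). Compound 2 `Cc1ccc2ncc(S(=O)(=O)c3ccc(F)cc3)c(N3CCC(C)CC3)c2c1` gives 90% in this assay.

Compound 2 has the lower of the two numbers, yet the step of a number 3 percentage points lower from compound 1 to compound 2 (within the scatter) lies within the scatter, so the two compounds cannot be told apart. Compound 3 `CC1CCN(c2c(S(=O)(=O)c3ccc(F)cc3)cnc3ccc(Cl)cc23)CC1` differs from compound 2 by chloro in place of methyl on an aromatic carbon. Among the measured compounds shown here, the one measured step, a number 3 percentage points lower from compound 1 to compound 2 (within the scatter), alters the group on the sulfonyl sulfur, not the fused ring, so no measured step bears on this change. With both measured compounds showing high inhibition, compound 3 is expected to stay close, a step of a number 2 percentage points lower from compound 2 to compound 3 (within the scatter) that is not beyond the scatter. Compound 3 is therefore estimated at 88%, with a range from 70% to 97%.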

Compound 3, a percentage reported as inhibition, at one concentration (the size of the read-out at that concentration, not a potency): 89%
The estimate for compound 3 lay 1 percentage points below the measured number; the range from low to high includes it.
By their numbers in this assay, from the lowest: compounds 3, 2 and 1 (each within the scatter of the next).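

The earlier step changed only the group on the sulfonyl sulfur, whereas this one changes the six-membered aromatic ring of carbon only. In this assay, chloro in place of methyl on this aromatic carbon gives a number 1 percentage points lower from compound 2 to compound 3 (within the scatter), so this position accepts either group without a readable change in inhibition at the concentration tested. No measured evidence here offers a reason for this result.

On these data alone, whether an amine or a carboxylic acid on this carbon would keep inhibition this high remains open. A single concentration also leaves open whether methyl and chloro compounds differ in potency.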